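The source may hold more compounds than are shown below. What is called first, only, known or untested is meant among the compounds shown, and "the series" means these compounds.

Measured in a functional assay on RAW264.7 cells (Mus musculus) for inhibition, read by Griess assay, with stated times of 2 h and 18 h; on this read-out lower numbers stand for stronger inhibition and higher numbers for weaker inhibition:

Compound 1 `C[C@@H]1C(=O)C(O)=C2C(C)(C)C(=O)CC[C@]2(C)[C@@]1(O)CCc1ccoc1`: > 50000 nM
Compound 2 `CC1=C(CCc2ccoc2)[C@@]2(C)CC[C@@H](O)C(C)(C)[C@@H]2[C@H](O)C1=O`: > 50000 nM

Neither entry is a true number. Compound 2 gives > 50000 nM, which is a limit of this assay. Compound 1 gives > 50000 nM, which is also a limit. Together they show (the limit of > 50000 nM in this assay, at which 2 of the 2 values shown sit), so the data give no measured potency to build on.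

Compound 3 `CC(=O)O[C@@H]1CC[C@]2(C)C(CCc3ccoc3)=C(C)C(=O)[C@@H](O)[C@H]2C1(C)C` changes compound 2 in one place, with acetyl in place of hydrogen on an oxygen on a saturated carbon, or hydroxy to acetoxy: acetyl in place of hydrogen on an oxygen on a saturated carbon. For the measured compounds named here, no measured pair shows what this change does in this assay. The expected outcome is therefore no shift beyond the usual scatter, and another limit is quite likely. The estimated step is an at least 1.1-fold lower number from compound 2 to compound 3 (0.04 log units; that floor lies within the scatter). For compound 3 the expected value is 45000 nM, with an estimated range from 15000 nM to 90000 nM.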

Compound 3, half-maximal inhibitory concentration: 22500 nM
Beside the measured number, compound 3's estimate is 2.0-fold (0.30 log units) above it, and the stated range covers the measured number.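

In this assay, acetyl in place of hydrogen on this oxygen gives the first true number among the compounds shown, and the change reads as an at least 2.2-fold lower number from compound 2 to compound 3 (0.34 log units; beyond the scatter). This shows that a change at this hydroxy group can move the read-out, which neither earlier compound could show. The step can only be given as a floor, because compound 2 stands at a limit and not at a true number: the limit of > 50000 nM in this assay, at which 2 of the 3 values shown sit.

The compounds shown leave open whether this shift belongs to acetyl in particular or would also come with another group on the same oxygen, such as a longer acyl chain like butanoyl, a benzoyl group or a simple methyl ether. They also leave open what an amine in place of this oxygen would do.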